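A few compounds are considered here, and "the series" means these few. Any claim that something is new, unique, unknown or untested is made for them only; others in the source may bear on it.

Measured compounds in this series:
Compound 1 `CCCN1CCC(C(=O)Nc2cc(Cl)c(N)cc2OC)CC1`: in a functional assay on the whole organism for antagonist activity, with Mus musculus as the target (on this read-out higher numbers stand for an effect only at larger amounts of compound and lower numbers for an effect already at smaller amounts), compound 1 gives > 10 mg/kg, a limit of the assay and not a number.
Compound 2 `CCC(CC)CN1CCC(C(=O)Nc2cc(Cl)c(N)cc2OC)CC1`: in this assay compound 2 gives > 10 mg/kg, again a limit.
Compound 3 `CCN1CCC(C(=O)Nc2cc(Cl)c(N)cc2OC)CC1`: in this assay compound 3 gives > 10 mg/kg, again a limit.

Compound 3 therefore stands at the limit of > 10 mg/kg in this assay, at which 3 of the 3 values shown sit; no measured number places it more exactly. The steps among the three measured compounds all run between such limits: a step that the two limits leave unreadable from compound 1 to compound 2, a step that the two limits leave unreadable from compound 1 to compound 3 and a step that the two limits leave unreadable from compound 2 to compound 3. None of them can be read for size or direction.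

Compound 4 `COc1cc(N)c(Cl)cc1NC(=O)C1CCN(CC2CCCCC2)CC1` differs from compound 3 by cyclohexyl in place of methyl on a saturated chain carbon bound to an amine nitrogen in a ring. Going by the values given here, the steps that bear on this change are those that alter the chain on the ring nitrogen, from compound 1 to compound 2 and from compound 2 to compound 3, and both are unreadable. Nothing in the measured data shows that lengthening or branching this chain moves the result in this assay in either direction. For compound 4 the expectation is accordingly a value near the limit, estimated at 15 mg/kg with a range from 4 mg/kg to 60 mg/kg. The step that the limit leaves unreadable from compound 3 to compound 4 is expected to stay within the scatter, with a real chance that compound 4 again returns only a limit.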

Compound 4, dose for half-maximal effect: 2.9 mg/kg
The estimate for compound 4 lay 5.2-fold (0.71 log units) above the measured number, outside the stated range (below it).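

In this assay the group on a saturated chain carbon bound to an amine nitrogen in a ring now has a readable effect: cyclohexyl in place of methyl gives an at least 3.4-fold lower number from compound 3 to compound 4 (0.53 log units; beyond the scatter), cyclohexyl in place of pentan-3-yl gives an at least 3.4-fold lower number from compound 2 to compound 4 (0.53 log units; beyond the scatter), and cyclohexyl in place of ethyl gives an at least 3.4-fold lower number from compound 1 to compound 4 (0.53 log units; beyond the scatter). The comparison with compound 2 matters most, as it shows that in this series a branched open chain and a six-membered carbon ring at this place are not interchangeable. Compound 1, compound 2 and compound 3 all remain at a limit of the assay and not at a number, so the steps among them cannot be read and each step to compound 4 gives only a minimum size: the limit of > 10 mg/kg in this assay, at which 3 of the 4 values shown sit.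

As far as these compounds go, it remains open whether the ring as such carries the change, since a cyclopentyl or a phenyl at the same place could give a number as well or stay at the limit. From the compounds shown here alone, it is also open whether a longer chain between the amine nitrogen and the cyclohexyl would keep, lose or extend the result seen with compound 4.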